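This account rests on a few compounds, and the source may have more. Where it says the series, first, only, none or still open, it means among the compounds named here.

Compounds measured so far:
compound 1 `O=C1COCCN1c1ccc(/N=C\c2cn(C(=O)c3ccc(Cl)cc3)c3ccccc23)cc1`: 90.3%
compound 2 `O=C1COCCN1c1ccc(/N=C\c2cn(Cc3ccccc3)c3ccccc23)cc1`: 58.7%

In an ADME assay on BV-2 cells (Mus musculus) for cytotoxicity, read by MTT assay, with a stated time of 48 h, tested at 80 uM (on this read-out higher numbers stand for a weaker effect at the one concentration tested and lower numbers for a stronger effect), compound 1 gives 90.3%. Compound 2 stands lowest of the two numbers; in this assay compound 2 gives 58.7%. For the measured compounds named here, the one measured step, a number 31.6 percentage points lower from compound 1 to compound 2 (beyond the scatter), is large, but it concerns an exchange on the aromatic nitrogen of the core and says nothing about a substituent on the benzyl ring.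

Compound 3 `O=C1COCCN1c1ccc(/N=C\c2cn(Cc3ccc(F)cc3)c3ccccc23)cc1` differs from compound 2 by fluoro in place of hydrogen on an aromatic carbon, that is, benzyl becomes 4-fluorobenzyl. Going by the values given here, no measured pair shows what this exchange does in this assay, so the account can rest only on compound 2 itself. The step expected in this assay is therefore none beyond the scatter, with the direction left open. Compound 3 is thus expected to give about 55% in this assay, estimated between 35% and 75%. The estimated step from compound 2 is a number 3.7 percentage points lower from compound 2 to compound 3 (within the scatter).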

Compound 3, a percentage reported as activity, at one concentration (the size of the read-out at that concentration, not a potency): 59%
The estimate for compound 3 lay 4 percentage points below the measured number; the range from low to high includes it.
By their numbers in this assay, from the lowest: compounds 2 and 3 (each within the scatter of the next); then compound 1.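

In this assay, fluoro in place of hydrogen on the aromatic carbon para to a large group gives a step of a number 0.3 percentage points higher from compound 2 to compound 3 (within the scatter), so this position of the benzyl ring accepts this one exchange with no readable difference on this read-out. The large step seen at the aromatic nitrogen with plain benzyl also appears with 4-fluorobenzyl, as a number 31.3 percentage points lower from compound 1 to compound 3 (beyond the scatter), so it does not depend on the hydrogen of compound 2 at that ring position. No measurement shown here gives a reason for either step.

The compounds shown leave open whether a larger or differently built group at the same ring position, such as an amine, a carboxylic acid or methoxy, would also leave the number within the scatter of compound 2. They also leave open what a longer chain in place of benzyl on the aromatic nitrogen would do in this assay.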